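A few compounds are considered here, and "the series" means these few. Any claim that something is new, unique, unknown or untested is made for them only; others in the source may bear on it.

Measured so far in a functional assay on cells for positive allosteric modulation of metabotropic glutamate receptor 5 (Rattus norvegicus), read by calcium flux; a lower number here means that less compound is needed, a higher number that more compound is needed for the effect:
- compound 1, `O=C(Nc1cc(-c2ccccc2)nn1-c1ccccc1)c1cccc(C(F)(F)F)c1`: 228 nM
- compound 2, `O=C(Nc1cc(-c2ccccc2)nn1-c1ccccc1F)c1ccccc1`: 104 nM
- compound 3, `N#Cc1cccc(C(=O)Nc2cc(-c3ccccc3)nn2-c2ccccc2Br)c1`: 50 nM

Compound 1 gives the highest number of the three in this assay. Compound 2 sits below it by a margin that lies beyond the scatter, and compound 3 lies further below, also beyond the scatter. No two of these compounds differ in one place only, so nothing can be read from them as a single step; the three values show only the spread of the set.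

The next compound is compound 4, `O=C(Nc1cc(-c2ccccc2)nn1-c1ccccc1)C1CCCCC1`. Against compound 1 the difference is cyclohexyl in place of 3-(trifluoromethyl)phenyl on a carbonyl carbon. Within the data shown here, nothing measured here isolates this change: every amide in the set carries an aromatic ring on the carbonyl carbon, and the other end of the shared core varies at the same time, so the size of the step has no precedent in these data.

The expectation is a move to a higher number, beyond the scatter, with the step from compound 1 to compound 4 estimated at a 3.5-fold higher number from compound 1 to compound 4 (0.55 log units; beyond the scatter). Compound 4 is expected to give about 800 nM in this assay. Among the measured compounds shown here, the estimate for compound 4 spans 250 nM to 3000 nM, the wide range reflecting that no measured pair here anchors the change.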

Compound 4, half-maximal effective concentration: > 10000 nM
Compound 4 gave a limit, no number; the forecaster's own chance of this, stated with the estimate: 20%; middle value at least 12-fold (1.09 log units) away from the limit.
By their numbers in this assay, from the lowest: compound 3; then compound 2; then compound 1. At a limit, above all of these: compound 4.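

In this assay, among these compounds, compound 4 gives > 10000 nM, which is a limit of the assay and not a number, and it is the only value in the set that sits there: the limit of > 10000 nM in this assay, at which 1 of the 4 values shown sits. Among the compounds shown here, this is the first step that changes one place only, and cyclohexyl in place of 3-(trifluoromethyl)phenyl on a carbonyl carbon gives an at least 43-fold higher number from compound 1 to compound 4 (1.64 log units; beyond the scatter), a large step whose full size stays unknown with one end at a limit. The group on the carbonyl carbon therefore matters a great deal in this assay: among the four compounds, compound 1, compound 2 and compound 3 carry an aromatic ring there and give numbers, while compound 4, with a non-aromatic ring, gives none.

The step removes the aromatic ring and the trifluoromethyl group together, so the compounds shown cannot tell which of the two changes carries the loss. Also open, as far as these compounds go, is how an open-chain group such as tert-butyl, or a ring amine such as piperidin-4-yl, on the same carbonyl carbon would read in this assay.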